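Tert-butyl added to the hydroxy analogue of the series

The source may report more compounds than this note shows. Statements on the series, on what has been measured and on what is new or still open speak of the compounds shown alone.

Among the measured compounds shown here, compound 3 `O=c1c(O)c(O)oc2ccc(O)cc12` gives 1520000 nM in a functional assay on the whole organism for inhibition, with Homo sapiens as the target (a lower number here means a stronger inhibitor, a higher number a weaker inhibitor), the highest of the two numbers so far. Its nearest neighbour, compound 1 `O=c1c(O)c(O)oc2ccc(Cl)cc12`, gives 513000 nM in this assay. Compound 2 `O=C1C(O)=C(O)OC12CCCCC2` reaches only a limit of this assay, > 3000000 nM, which is the limit of > 3000000 nM in this assay, at which 1 of the 3 values shown sits. For the measured compounds named here, the single measured step, a 3.0-fold higher number from compound 1 to compound 3 (0.47 log units; beyond the scatter), is modest but beyond the scatter.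

Compound 4 `CC(C)(C)c1cc2oc(O)c(O)c(=O)c2cc1O` differs from compound 3 by tert-butyl in place of hydrogen on an aromatic carbon. Going by the values given here, no measured step adds a group at that place: the one step known swaps a substituent at another position of the same ring, so it shows only that a single change on that ring moves this assay by a modest amount. The direction for an added tert-butyl cannot be read from the data. A modest shift, direction open, is therefore expected for compound 4, a 1.5-fold lower number from compound 3 to compound 4 (0.18 log units; within the scatter). The estimate for compound 4 in this assay is 1000000 nM, with a range from 250000 nM to 4000000 nM.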

Compound 4, half-maximal inhibitory concentration: 2180000 nM
The estimate for compound 4 lay 2.2-fold (0.34 log units) below the measured number; low and high end bracket the measured number.
By their numbers in this assay, from the lowest: compound 1; then compounds 3 and 4 (each within the scatter of the next). At a limit, above all of these: compound 2.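

With tert-butyl in place of hydrogen on this aromatic carbon, ortho to a hydroxy group, this assay shows a 1.4-fold higher number from compound 3 to compound 4 (0.16 log units; within the scatter). Among the compounds shown here, at this place, then, a group of 4 heavy atoms is carried with no difference that can be told from the scatter, whereas the only earlier step, a 3.0-fold higher number from compound 1 to compound 3 (0.47 log units; beyond the scatter), a swap of chloro for hydroxy, lies beyond it. Compound 2 remains the only compound at a limit: the limit of > 3000000 nM in this assay, at which 1 of the 4 values shown sits.

On these data alone, whether an amine, a carboxylic acid or a longer chain at this place would give a step beyond the scatter stays open. Also open, as far as these compounds go, is whether tert-butyl would read the same on the core of compound 1, which carries chloro where compound 3 carries hydroxy.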